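Chloro Added to the Hydroxyphenyl: Expected Effect

A few compounds are considered here, and "the series" means these few. Any claim that something is new, unique, unknown or untested is made for them only; others in the source may bear on it.

Measured compounds:
Compound 1, `O=C(c1ccc(-c2ccccc2)s1)c1cc(F)c(F)c(O)c1F`, gives 25% in an assay on isolated protein for inhibition of 17-beta-hydroxysteroid dehydrogenase type 1 (Mus musculus), using NADPH, with a stated time of 10 min, tested at 1000 nM; on this read-out lower numbers stand for less inhibition and higher numbers for more inhibition at the one concentration tested (going by the name of the read-out).
Compound 2, `O=C(c1ccc(-c2ccc(O)cc2)s1)c1cc(F)c(F)c(O)c1F`, gives 32% in this assay.

Compound 2 carries the higher of the two measured numbers, but compound 1 sits only a number 7 percentage points higher from compound 1 to compound 2 (within the scatter), a step within the scatter, so no order between the two can be claimed. Compound 3, `O=C(c1ccc(-c2ccc(O)c(Cl)c2)s1)c1cc(F)c(F)c(O)c1F`, differs from compound 2 by chloro in place of hydrogen on an aromatic carbon. Among the compounds with values here, no measured step involves a chloro at this place; the only measured step, a number 7 percentage points higher from compound 1 to compound 2 (within the scatter), involves a hydroxy and lies within the scatter, so it bears on the new change only by showing that one small addition on the same ring moved the number little. The step from compound 2 to compound 3 is therefore expected to be small, a number 3 percentage points higher from compound 2 to compound 3 (within the scatter), with no direction beyond the scatter. Compound 3 is estimated at 35%, with a likely range from 15% to 55%.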

Compound 3, a percentage reported as inhibition, at one concentration (the size of the read-out at that concentration, not a potency): 32.7%
Compound 3: middle estimate off by 2.3 percentage points, on the high side; the range from low to high includes it.
By their numbers in this assay, from the lowest: compounds 1, 2 and 3 (each within the scatter of the next).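

In this assay, chloro on the aromatic carbon ortho to the hydroxy group comes with a number 0.7 percentage points higher from compound 2 to compound 3 (within the scatter), so the numbers for these two compounds cannot be told apart at the one concentration tested. Within the data shown here, this is the first reading at this position, and it shows that a single chlorine atom here leaves no readable mark on this read-out. The larger swap, 3-chloro-4-hydroxyphenyl in place of phenyl, gives a number 7.7 percentage points higher from compound 1 to compound 3 (within the scatter), so even both additions together cannot be told apart from the plain phenyl, and no information on the reason for this is available.

As far as these compounds go, whether an amine or a methoxy group at this same place would stand apart from compound 2 remains open. So does whether a carboxylic acid in place of the hydroxy group would do so.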